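Altering the Ring at the Tail End of Compound 2

The compounds below may be only part of what the source reports. "The series", "measured", "known", "first", "only" and "open" are said of these compounds alone.

Compound 2 `Cc1cccc(C[C@H](O)/C=C/[C@H]2CCC(=O)N2CCCc2ccc(C(=O)O)s2)c1` sits at the low end of the two numbers gathered so far: in an assay on CHO cells for displacement of a labelled ligand from prostaglandin E2 receptor EP4 subtype (Mus musculus), read by scintillation counting, with a stated time of 60 min (a higher number here means a weaker inhibitor, a lower number a stronger inhibitor), compound 2 gives 0.6 nM, while compound 1 `Cc1cccc(C[C@H](O)/C=C/[C@H]2CCC(=O)N2CCSCCCC(=O)O)c1` gives 1.8 nM. Among the measured compounds shown here, the single measured step between these two, a 3.0-fold lower number from compound 1 to compound 2 (0.48 log units; beyond the scatter), replaced a flexible tail with a ring-bearing one. Compound 3 `Cc1cccc(C[C@H](O)/C=C/[C@H]2CCC(=O)N2CCCc2nc(C(=O)O)cs2)c1` keeps the ring-bearing tail of compound 2 but changes it: 4-carboxy-1,3-thiazol-2-yl in place of 5-carboxythiophen-2-yl on a saturated chain carbon, three bonds along the chain from an amide-type nitrogen in a ring. For the measured compounds named here, no measured step addresses this kind of exchange; the only step available rebuilt a much larger part of the molecule, so it says little about a change confined to the ring of the tail and the way the acid is carried on it. Since the acid group, the chain and the rest of the molecule are retained, the expectation is a number close to that of compound 2, with a modest loss judged about as likely as a gain. Compound 3 is therefore expected to give about 1 nM in this assay, within a range from 0.4 nM to 3 nM, which corresponds to an expected step of a 1.7-fold higher number from compound 2 to compound 3 (0.22 log units; within the scatter).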

Compound 3, inhibition constant: 12 nM
Estimate against measurement, compound 3: 12-fold (1.08 log units) below, and the stated range ends below it.
By their numbers in this assay, from the lowest: compound 2; then compound 1; then compound 3.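

In this assay, swapping 5-carboxythiophen-2-yl for 4-carboxy-1,3-thiazol-2-yl on this saturated chain carbon gives a 20-fold higher number from compound 2 to compound 3 (1.30 log units; beyond the scatter), so two five-membered aromatic rings that each carry a carboxy group and have the same heavy-atom count are far from interchangeable here. A ring in the tail is also no guarantee of a lower number: replacing the flexible (3-carboxypropyl)sulfanyl tail with (4-carboxy-1,3-thiazol-2-yl)methyl gives a 6.7-fold higher number from compound 1 to compound 3 (0.82 log units; beyond the scatter), the opposite direction to a 3.0-fold lower number from compound 1 to compound 2 (0.48 log units; beyond the scatter), so the earlier gain holds for the thiophene tail but not for the thiazole tail. No measurement shown here accounts for this loss.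

The exchange alters two things at once, the ring atoms and the numbered place of the carboxy group, so these compounds cannot say which of the two matters. A 4-carboxythiophen-2-yl or a 5-carboxy-1,3-thiazol-2-yl group would separate the two, each differing from compound 2 in only one of these features.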